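Urea series: hydroxy for methyl on the central ring

The source may report more compounds than this note shows. Statements on the series, on what has been measured and on what is new or still open speak of the compounds shown alone.

Three measured compounds share the core of compound 1 `O=C(Nc1ccc(Br)cc1)Nc1ccc(Nc2ncnc3c2OCCN3)cc1`, which in an assay on isolated protein for inhibition of proto-oncogene tyrosine-protein kinase receptor Ret (Homo sapiens), read by 33P incorporation, with stated times of 15 min and 40 min (on this read-out higher numbers stand for weaker inhibition and lower numbers for stronger inhibition), gives 2220 nM. Compound 2 `CC(C)(C)c1cc(NC(=O)Nc2ccc(Nc3ncnc4c3OCCN4)cc2)no1` gives 10 nM; the step of a 220-fold lower number from compound 1 to compound 2 (2.35 log units; beyond the scatter) came with 5-(tert-butyl)-1,2-oxazol-3-yl in place of 4-bromophenyl on an amide-type nitrogen. Compound 3 `Cc1cc(NC(=O)Nc2cc(C(C)(C)C)on2)ccc1Nc1ncnc2c1OCCN2` gives 50 nM and stands second highest of the three numbers, between compound 1 and compound 2; the step of a 5.0-fold higher number from compound 2 to compound 3 (0.70 log units; beyond the scatter) came with methyl in place of hydrogen on an aromatic carbon. Compound 4 `CC(C)(C)c1cc(NC(=O)Nc2ccc(Nc3ncnc4c3OCCN4)c(O)c2)no1` carries hydroxy in place of methyl on an aromatic carbon. For the measured compounds named here, only the methyl step bears on it, and it was modest; a hydroxy at this place has no measured precedent, so the methyl-to-hydroxy change is expected to give a small step, possibly back toward compound 2. Compound 4 is expected near 30 nM, between 8 nM and 120 nM. That corresponds to an expected step of a 1.7-fold lower number from compound 3 to compound 4 (0.22 log units; within the scatter).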

Compound 4, half-maximal inhibitory concentration: 25 nM
Compound 4: the middle estimate sits 1.2-fold (0.08 log units) above what was measured, and the stated range covers the measured number.
By their numbers in this assay, from the lowest: compound 2; then compounds 4 and 3 (each within the scatter of the next); then compound 1.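

On this aromatic carbon, hydroxy and methyl cannot be told apart (a 2.0-fold lower number from compound 3 to compound 4 (0.30 log units; within the scatter)), although hydroxy brings a hydrogen-bond donor and acceptor that methyl lacks. Hydroxy in place of hydrogen still gives a step beyond the scatter (a 2.5-fold higher number from compound 2 to compound 4 (0.40 log units; beyond the scatter)), so in the two substituted compounds shown, compound 3 and compound 4, neither group reaches the low number of compound 2. No evidence shown here accounts for this result.

Open, as far as these compounds go, is whether a methoxy, a fluorine or an amine here would return to the number of compound 2. Also open, from the compounds shown here alone, is whether hydroxy in place of hydrogen gives a similar step with the 4-bromophenyl of compound 1.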